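Carbamate ester variation at a fluorinated alkyl group

The source may report more compounds than this note shows. Statements on the series, on what has been measured and on what is new or still open speak of the compounds shown alone.

Compound 1 `Cc1nc(S(C)(=O)=O)ccc1Oc1ncnc(OC2CCN(C(=O)OC(C)(C)C(F)(F)F)CC2)c1F`: 47.2 nM
Compound 2 `Cc1nc(S(C)(=O)=O)ccc1Oc1ncnc(OC2CCN(C(=O)OC(C)(C)CF)CC2)c1F`: 138 nM

Among the measured compounds shown here, of the two numbers measured in a functional assay on isolated protein for inhibition of Glucose-dependent insulinotropic receptor (Rattus norvegicus), read by HTRF and cAMP accumulation (on this read-out lower numbers stand for an effect already at smaller amounts and higher numbers for an effect only at larger amounts of compound), compound 2 stands at the highest, its only neighbour being compound 1. For the measured compounds named here, the sole measured step is a 2.9-fold higher number from compound 1 to compound 2 (0.47 log units; beyond the scatter), and that step concerns the fluorination of the group, not its size.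

Compound 3 `Cc1nc(S(C)(=O)=O)ccc1Oc1ncnc(OC2CCN(C(=O)O[C@H](C)CF)CC2)c1F` is the next member: 1-(fluoromethyl)ethyl in place of 1-(fluoromethyl)-1-methylethyl on an oxygen next to a carbonyl group. Going by the values given here, no measured step shows the loss of a methyl at this position, so the direction of the change is open. Among the compounds with values here, the one step in hand, within the same place of the molecule, was modest in size, and a step of similar magnitude or less is expected here, without a clear direction. For compound 3 the estimate in this assay is 150 nM, within a range of 50 nM to 450 nM, which means an expected step of a 1.1-fold higher number from compound 2 to compound 3 (0.04 log units; within the scatter).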

Compound 3, half-maximal effective concentration: 1520 nM
Estimate against measurement, compound 3: 10-fold (1.01 log units) below, outside the stated range (above it).
By their numbers in this assay, from the lowest: compound 1; then compound 2; then compound 3.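

In this assay, the loss of one methyl from the 1-(fluoromethyl)-1-methylethyl group on the oxygen next to a carbonyl group gives an 11-fold higher number from compound 2 to compound 3 (1.04 log units; beyond the scatter), so this position responds strongly to the size of the group as well as to its fluorination. Taking the fluorine change and the methyl loss together, the replacement of 1-methyl-1-(trifluoromethyl)ethyl by 1-(fluoromethyl)ethyl amounts to a 32-fold higher number from compound 1 to compound 3 (1.51 log units; beyond the scatter). Nothing shown here explains why the methyl matters so much at this position.

The entering group also brings a defined stereocentre, so the shown compounds cannot separate the methyl loss from the effect of that stereocentre, and the opposite mirror-image form of 1-(fluoromethyl)ethyl remains open. Also open, as far as these compounds go, is whether 1-(trifluoromethyl)ethyl or a cyclopropyl group would behave like the 1-methyl-1-(trifluoromethyl)ethyl group of compound 1.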